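The source may report more compounds than this note shows. Statements on the series, on what has been measured and on what is new or still open speak of the compounds shown alone.

In a functional assay on A549 cells (Homo sapiens) for inhibition, read by MTT assay, with a stated time of 72 h (on this read-out higher numbers stand for weaker inhibition and lower numbers for stronger inhibition), compound 3 (`C=CC(=O)Nc1cc(Nc2nc3c(c(-c4cn(C)c5ccc(F)cc45)n2)CS(=O)(=O)CC3)c(OC)cc1N(C)CCN(C)C`) gives 4640 nM, within the scatter of compound 2 (`C=CC(=O)Nc1cc(Nc2nc3c(c(-c4cn(C)c5ccccc45)n2)CS(=O)(=O)CC3)c(OC)cc1N(C)CCN(C)C`) at 8690 nM. Both numbers are higher than that of compound 1 (`COc1cc(N(C)CCN(C)C)c(NC(=O)C=C(C)C)cc1Nc1nc2c(c(-c3cn(C)c4ccc(F)cc34)n1)CSCC2`) at 902 nM, though compound 1 differs from compound 3 in more than one place. Compound 4 (`C/C=C\C(=O)Nc1cc(Nc2nc3c(c(-c4cn(C)c5ccc(F)cc45)n2)CS(=O)(=O)CC3)c(OC)cc1N(C)CCN(C)C`) has prop-1-en-1-yl in place of vinyl on a carbonyl carbon. Among the compounds with values here, the only measured single-place step, a 1.9-fold lower number from compound 2 to compound 3 (0.27 log units; within the scatter), is fluoro in place of hydrogen on an aromatic carbon, within the scatter, and it leaves that carbonyl untouched. Within the data shown here, no measured step therefore tests this change, and little movement in this assay is assumed. The expected outcome is a 1.2-fold higher number from compound 3 to compound 4 (0.07 log units; within the scatter), a slightly higher number but not beyond the scatter. For compound 4 the estimate is 5500 nM, with an expected range of 2500 nM to 12000 nM.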

Compound 4, half-maximal inhibitory concentration: 3990 nM
Compound 4: the middle estimate sits 1.4-fold (0.14 log units) above what was measured, and the stated range covers the measured number.
By their numbers in this assay, from the lowest: compound 1; then compounds 4, 3 and 2 (each within the scatter of the next, the first and the last beyond it).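

In this assay, prop-1-en-1-yl in place of vinyl on a carbonyl carbon gives a 1.2-fold lower number from compound 3 to compound 4 (0.07 log units; within the scatter) and so lies within the scatter. Within the data shown here, this is the first measured step at this position, and it shows that this swap of vinyl for the slightly larger chain on the amide carbonyl leaves the two compounds indistinguishable in this assay. Nothing shown offers a reason for this result.

The compounds shown leave open whether a longer chain or a dimethylamino group at this carbonyl carbon would also stay within the scatter.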